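The source may report more compounds than this note shows. Statements on the series, on what has been measured and on what is new or still open speak of the compounds shown alone.

Measured in a functional assay on PA-1 cells (Homo sapiens) for cytotoxicity, read by MTT assay, with stated times of 6 h and 48 h; a lower number here means a stronger inhibitor, a higher number a weaker inhibitor:
compound 1 `Cn1c(/C=C/C(=O)c2cccc(O)c2)cc(Br)c1Br`: >= 100000 nM, a limit of the assay
compound 2 `Cn1c(/C=C/C(=O)c2ccc(O)cc2O)cc(Br)c1Br`: 830 nM
compound 3 `Cn1c(/C=C/C(=O)c2ccc(O)cc2)cc(Br)c1Br`: 2850 nM

Compound 1 sits at the limit of >= 100000 nM in this assay, at which 1 of the 3 values shown sits, and gives no number. Compound 3 has the same atoms as compound 1, joined differently; the difference between the two cores is not broken down here. From compound 3 to compound 2 the change is hydroxy in place of hydrogen on an aromatic carbon, which made a 3.4-fold lower number from compound 3 to compound 2 (0.54 log units; beyond the scatter). Compound 4 `Cn1c(/C=C/C(=O)c2cc(O)ccc2O)cc(Br)c1Br`, not yet measured, arises from compound 1 by hydroxy in place of hydrogen on an aromatic carbon, the same kind of change, though here the entering hydroxy is para to a hydroxy group, whereas in compound 2 it is meta to a hydroxy group. Compound 4 is expected to move from compound 1 by an at least 2.5-fold lower number from compound 1 to compound 4 (0.39 log units; beyond the scatter) in this assay, resting on a 3.4-fold lower number from compound 3 to compound 2 (0.54 log units; beyond the scatter) and on the limit (the limit of >= 100000 nM in this assay, at which 1 of the 3 values shown sits). Compound 4 is estimated at 40000 nM, between 8000 nM and 150000 nM.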

Compound 4, half-maximal inhibitory concentration: 380 nM
The estimate for compound 4 lay 110-fold (2.02 log units) above the measured number; the measured number lies below the stated range.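

In this assay, hydroxy in place of hydrogen on an aromatic carbon gave an at least 260-fold lower number from compound 1 to compound 4 (2.42 log units; beyond the scatter), and the size of the step did not carry over from one core to the other: the same change on two cores in this assay, a 3.4-fold lower number (0.54 log units; beyond the scatter) from compound 3 to compound 2 and an at least 260-fold lower number (2.42 log units; beyond the scatter) from compound 1 to compound 4, at least 76-fold (1.88 log units) apart, beyond the scatter of two such steps. The larger step is open at one end, as compound 1 stands at a limit of the assay and gives no number: the limit of >= 100000 nM in this assay, at which 1 of the 4 values shown sits. Both steps lower the number, but with a single pair on each core they do not show what sets their sizes apart, for in compound 4 the entering hydroxy sits para to a hydroxy group and the core differs as well. The compounds shown leave open whether a methoxy group or an amine in that place would lower the number as hydroxy does.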